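This account rests on a few compounds, and the source may have more. Where it says the series, first, only, none or still open, it means among the compounds named here.

Measured compounds in a functional assay on HL-60 cells (Homo sapiens) for antiproliferative activity, with a stated time of 24 h; on this read-out lower numbers stand for stronger inhibition and higher numbers for weaker inhibition:
compound 1, `NC(=O)c1c(NC(=O)c2ccccc2Cl)sc2c1CCN(C(=S)Nc1ccccc1F)C2`, 4970 nM
compound 2, `NC(=O)c1c(NC(=O)c2ccccc2C(F)(F)F)sc2c1CCN(C(=S)Nc1ccccc1Cl)C2`, 17600 nM
compound 3, `NC(=O)c1c(NC(=O)c2ccc(C(F)(F)F)cc2)sc2c1CCN(C(=S)Nc1ccccc1Cl)C2`, 36100 nM

Among these three numbers compound 2 stands second highest; compound 3 sits nearest to it, while compound 1 gives the lowest number of the set. Going by the values given here, the one measured step, a 2.1-fold higher number from compound 2 to compound 3 (0.31 log units; beyond the scatter), concerns the benzoyl side and is modest in size. Compound 4, `NC(=O)c1c(NC(=O)c2ccccc2C(F)(F)F)sc2c1CCN(C(=S)Nc1ccccc1F)C2`, differs from compound 2 elsewhere: fluoro in place of chloro on an aromatic carbon. Among the compounds with values here, no measured step touches this position, and compound 1 differs from compound 2 in two places, so only its value can be noted. In this assay compound 4 is therefore expected to give 12000 nM, within 5000 nM to 30000 nM, a step of a 1.5-fold lower number from compound 2 to compound 4 (0.17 log units; within the scatter) that may well stay within the scatter.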

Compound 4, half-maximal inhibitory concentration: 23500 nM
Compound 4: middle estimate off by 2.0-fold (0.29 log units), on the low side, and the stated range covers the measured number.
By their numbers in this assay, from the lowest: compound 1; then compounds 2, 4 and 3 (each within the scatter of the next, the first and the last beyond it).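

In this assay, 2-fluorophenyl in place of 2-chlorophenyl gives a 1.3-fold higher number from compound 2 to compound 4 (0.13 log units; within the scatter), so these two halogens cannot be told apart at this position. Compound 4 also makes a new single-change comparison on the benzoyl side, where trifluoromethyl in place of chloro gives a 4.7-fold higher number from compound 1 to compound 4 (0.67 log units; beyond the scatter), showing that this change on the other ring does move the number. Nothing available explains either step.

From the compounds shown here alone, what a larger group at the halogen position, such as methoxy or an amine, would do remains open. So does whether an unsubstituted phenyl there would give a different number.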